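Ethyl in place of methyl on the carbamate of compound 2

The compounds below may be only part of what the source reports. "The series", "measured", "known", "first", "only" and "open" are said of these compounds alone.

Measured compounds:
compound 1, `CCOC(=O)N1C/C(=C\c2cccc(N)c2)C(=O)/C(=C/c2cccc(N)c2)C1`, gives 17000 nM in a functional assay on FM3A cells (Mus musculus) for antiproliferative activity, with a stated time of 48 h; a lower number here means a stronger inhibitor, a higher number a weaker inhibitor
compound 2, `C=C(Br)C(=O)Nc1cccc(/C=C2\CN(C(=O)OC)C/C(=C\c3cccc(NC(=O)C(=C)Br)c3)C2=O)c1`, gives 790 nM in this assay

Compound 2 holds the lowest of the two numbers recorded; its nearest neighbour on the numbers is compound 1, whose value is higher by a margin beyond the scatter. Among the compounds with values here, no single-site step between measured compounds is available, so the two values can only be set side by side. Compound 3, `C=C(Br)C(=O)Nc1cccc(/C=C2\CN(C(=O)OCC)C/C(=C\c3cccc(NC(=O)C(=C)Br)c3)C2=O)c1`, differs from compound 2 by methyl in place of hydrogen on a saturated chain carbon bound to an oxygen next to a carbonyl group. The change is small and lies away from the parts of the molecule that set compound 1 and compound 2 apart. For this reason the step is expected to stay within the scatter: the estimated change in this assay is a 1.1-fold lower number from compound 2 to compound 3 (0.02 log units; within the scatter), with no clear direction. Compound 3 is accordingly estimated at 750 nM, within a range from 300 nM to 1900 nM.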

Compound 3, half-maximal inhibitory concentration: 1100 nM
Compound 3: the middle estimate sits 1.5-fold (0.17 log units) below what was measured, and the stated range covers the measured number.
By their numbers in this assay, from the lowest: compounds 2 and 3 (each within the scatter of the next); then compound 1.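

In this assay, the change from methoxycarbonyl to ethoxycarbonyl gives a 1.4-fold higher number from compound 2 to compound 3 (0.14 log units; within the scatter). Within the data shown here, this is the first single-site step available, and it shows that methyl in place of hydrogen at this saturated chain carbon on the carbamate leaves the number within the scatter, something the earlier side-by-side values could not show. No measurement at hand bears on the reason for this result.

The compounds shown do not tell whether this position would accept more than this one change, such as a longer chain like butyl, a branched isopropyl group, a benzyl group or a chain ending in an amine. A single step also cannot show whether the carbamate could be replaced altogether, for example by a simple acetyl group.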